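Benzylthio triazole and thiadiazole pyrazines: bromo to hydrogen

A few compounds are considered here, and "the series" means these few. Any claim that something is new, unique, unknown or untested is made for them only; others in the source may bear on it.

Measured so far:
compound 1, `Fc1ccccc1CSc1nnc(-c2cnccn2)s1`: 18400 nM
compound 2, `Brc1ccccc1CSc1nnc(-c2cnccn2)n1-c1ccccc1`: 36200 nM

In a functional assay on BGC-823 cells (Homo sapiens) for antiproliferative activity, read by MTT assay, with a stated time of 48 h (on this read-out lower numbers stand for stronger inhibition and higher numbers for weaker inhibition), compound 1 gives 18400 nM and compound 2 gives 36200 nM. The two numbers lie within the scatter of each other, so neither compound can be set apart from the other on the evidence in hand; compound 2 is simply the only triazole carrying both the phenyl on the core and the 2-bromobenzyl group. Within the data shown here, compounds 1 and 2 differ in more than one place, so no single step connects them and no step is counted.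

Compound 3, `c1ccc(CSc2nnc(-c3cnccn3)n2-c2ccccc2)cc1`, is still to be measured in this assay. Its change from compound 2 is hydrogen in place of bromo on an aromatic carbon. Among the measured compounds shown here, no measured pair shows the same change, so the size of the step rests on expectation only. The step from compound 2 to compound 3 is expected to be small, most likely a slight weakening or none beyond the scatter, as a 1.2-fold higher number from compound 2 to compound 3 (0.06 log units; within the scatter). In this assay compound 3 is expected to give about 42000 nM, within a range from 15000 nM to 110000 nM.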

Compound 3, half-maximal inhibitory concentration: > 50000 nM
Compound 3 gave a limit, no number; the forecaster's own chance of this, stated with the estimate: 15%; middle value at least 1.1-fold (0.07 log units) away from the limit.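

In this assay compound 3 gives > 50000 nM, which is a limit of the assay and not a number. Among these compounds, this is the first comparison that changes one place only, 2-bromobenzyl to benzyl on an otherwise unchanged structure, and it reads as an at least 1.3-fold higher number from compound 2 to compound 3 (0.14 log units; that floor lies within the scatter), so only a floor is known, and that floor alone neither sets the two compounds apart nor shows them to be alike. The full size of the step stays unfixed, because the value for compound 3 is a limit, so the part played by bromo on this aromatic carbon can be bounded from one side only: the limit of > 50000 nM in this assay, at which 1 of the 3 values shown sits.

The compounds shown leave open what a methoxy group or an amine on that same aromatic carbon would give, and whether any group there would yield a number clearly apart from that of compound 2. Compound 1 differs from compound 2 in more than one place, so its fluoro group cannot be read against the bromo.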